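From Bromo to Fluoro: Compound 2 to Compound 3

The source may hold more compounds than are shown below. What is called first, only, known or untested is meant among the compounds shown, and "the series" means these compounds.

Compound 2 `O=c1ccoc2cc(OCc3cn(Cc4cccc(Br)c4)nn3)ccc12` was examined in a functional assay on SGC-7901 cells (Homo sapiens) for cytotoxicity, read by MTT assay, with a stated time of 48 h; a higher number here means a weaker inhibitor, a lower number a stronger inhibitor. In this assay compound 2 gives only a limit of > 100000 nM, not a number. Compound 1 `O=c1ccoc2cc(OCc3cn(Cc4ccc(Cl)cc4)nn3)ccc12` is its nearest measured relative. In this assay compound 1 likewise reaches only the limit of > 100000 nM. The step that the two limits leave unreadable from compound 1 to compound 2 thus cannot be sized from the two values; what can be said is the limit of > 100000 nM in this assay, at which 2 of the 2 values shown sit. Compound 3 `O=c1ccoc2cc(OCc3cn(Cc4cccc(F)c4)nn3)ccc12` differs from compound 2 by fluoro in place of bromo on an aromatic carbon. Within the data shown here, no measured step bears directly on this change, and the single step in hand is unreadable, so no movement in this assay beyond the scatter can be foreseen in either direction. Compound 3 is therefore expected to sit at the limit as well, with an estimated 150000 nM (range 50000 nM to 500000 nM). The step that the limit leaves unreadable from compound 2 to compound 3 is accordingly expected to be nil.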

Compound 3, half-maximal inhibitory concentration: > 100000 nM
Compound 3: no number, only a limit; the forecaster's own chance of this, stated with the estimate: 80%; the middle value lies beyond the limit too.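

In this assay, among these compounds, compound 3 gives > 100000 nM, a limit and not a number, so no step linking it to compound 1 or compound 2 can be read. The three compounds share one result: the limit of > 100000 nM in this assay, at which 3 of the 3 values shown sit. Left open is whether they differ at all in this assay, and what structure would give a readable value.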